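Removing the methoxy from compound 2: expected cytotoxicity

The source may hold more compounds than are shown below. What is called first, only, known or untested is meant among the compounds shown, and "the series" means these compounds.

Three compounds share one core and differ only in the aryl group carried on the oxygen. In an ADME assay on MT4 cells (Homo sapiens) for cytotoxicity, read by MTT assay, with a stated time of 4 days (on this read-out lower numbers stand for higher toxicity in this test and higher numbers for lower toxicity in this test), compound 1 `Cc1cccc(Oc2nc(Nc3ccc(C#N)cc3)nc3ccccc23)c1` gives 355000 nM, compound 2 `COc1ccccc1Oc1nc(Nc2ccc(C#N)cc2)nc2ccccc12` gives 150000 nM, and compound 3 `Cc1cccc(C)c1Oc1nc(Nc2ccc(C#N)cc2)nc2ccccc12` gives 35000 nM. Compound 2 stands second highest of the three: a 2.4-fold lower number from compound 1 to compound 2 (0.37 log units; beyond the scatter), while a 4.3-fold lower number from compound 2 to compound 3 (0.63 log units; beyond the scatter). The widest gap is a 10-fold lower number from compound 1 to compound 3 (1.01 log units; beyond the scatter).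

Compound 4 `N#Cc1ccc(Nc2nc(Oc3ccccc3)c3ccccc3n2)cc1` has not yet been measured in this assay. It differs from compound 2 in one place: hydrogen in place of methoxy on an aromatic carbon. All three measured steps bear on it, since each of them changes only the substituents on that same aryl group. Going from one substituent to two gave the large drop between compound 1 and compound 3, and the change from 3-methylphenyl to 2-methoxyphenyl gave the modest drop between compound 1 and compound 2. Stripping the last substituent off is expected to move the number modestly upward, that is, toward lower toxicity: a 1.7-fold higher number from compound 2 to compound 4 (0.22 log units; within the scatter). Compound 4 is therefore estimated at about 250000 nM, with a range from 100000 nM to 600000 nM.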

Compound 4, half-maximal cytotoxic concentration: 370000 nM
Beside the measured number, compound 4's estimate is 1.5-fold (0.17 log units) below it, and the stated range covers the measured number.
By their numbers in this assay, from the lowest: compound 3; then compound 2; then compounds 1 and 4 (each within the scatter of the next).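

Compound 4, with a plain phenyl on the oxygen, gives a baseline for the substituents on this ring: in this assay, removing the methoxy gives a 2.5-fold higher number from compound 2 to compound 4 (0.39 log units; beyond the scatter), so the 2-methoxyphenyl group does lower the number relative to phenyl. The 3-methylphenyl group shows no such shift, with a 1.0-fold higher number from compound 1 to compound 4 (0.02 log units; within the scatter), whereas the 2,6-dimethylphenyl group stands far from phenyl, with an 11-fold higher number from compound 3 to compound 4 (1.02 log units; beyond the scatter), so among these four compounds, the two groups named with a substituent at position 2 lower the number and the 3-methylphenyl group does not. No measurement is available here that explains these differences.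

Going by these compounds, it remains open whether 2-methylphenyl, with a single methyl, would fall nearer compound 2 or compound 3. On these data alone, the effect of an amine, a hydroxyl or a chlorine on this ring also remains unknown.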